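Shortening the amine-bearing chain on the sulfonyl side

A few compounds are considered here, and "the series" means these few. Any claim that something is new, unique, unknown or untested is made for them only; others in the source may bear on it.

In an assay on HEK293 cells for displacement of a labelled ligand from growth hormone secretagogue receptor type 1 (Homo sapiens), with a stated time of 60 min (on this read-out higher numbers stand for weaker inhibition and lower numbers for stronger inhibition), compound 2 `COCCNCCCS(=O)(=O)c1ccc2nc(NC(=O)NC(=O)c3ccccc3Cl)sc2c1` gives 8.6 nM, the lower of the two numbers found, with compound 1 `Cc1ccnn1-c1ccc(Cl)c(C(=O)NC(=O)Nc2nc3ccc(S(=O)(=O)C4CCN(C)CC4)cc3s2)c1` at 33 nM, a gap beyond the scatter. Compound 3 `CS(=O)(=O)c1ccc2nc(NC(=O)NC(=O)c3ccccc3Cl)oc2c1` reaches only the limit of this assay, > 10000 nM, which is a limit and not a number; it differs from compound 2 in more than one place, so no single change can be read from it (the limit of > 10000 nM in this assay, at which 1 of the 3 values shown sits).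

Compound 4 `CC(C)NCCS(=O)(=O)c1ccc2nc(NC(=O)NC(=O)c3ccccc3Cl)sc2c1` carries isopropylamino in place of ((2-methoxyethyl)amino)methyl on a saturated chain carbon, two bonds along the chain from a sulfonyl sulfur. For the measured compounds named here, no step between two measured compounds tracks this change alone. The basic amine on the chain is kept, with the chain cut shorter and the methoxy group gone. Compound 2 and compound 1, which differ in what sits on the sulfonyl, both stay well below the limit, so the sulfonyl-linked amines tolerate change here. Compound 4 is therefore expected to stay close to compound 2, with a step of a 1.4-fold higher number from compound 2 to compound 4 (0.14 log units; within the scatter) not beyond the scatter. The estimate for compound 4 in this assay is 12 nM, expected between 4 nM and 40 nM.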

Compound 4, half-maximal inhibitory concentration: 27 nM
The estimate for compound 4 lay 2.3-fold (0.35 log units) below the measured number; low and high end bracket the measured number.
By their numbers in this assay, from the lowest: compound 2; then compounds 4 and 1 (each within the scatter of the next). At a limit, above all of these: compound 3.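

In this assay, for the compounds shown here, the change from (3-((2-methoxyethyl)amino)propyl)sulfonyl to (2-(isopropylamino)ethyl)sulfonyl gives a 3.1-fold higher number from compound 2 to compound 4 (0.50 log units; beyond the scatter) as a modest weakening, and it is the first step at this position that can be read in one place. Compound 4 still gives a number, 27 nM in this read-out, so this position accepts the shorter chain without the methoxy group, at a measurable but real cost. Nothing measured here explains the size of this step.

The step changes the chain and its end group together, so the compounds shown do not separate the two effects; isopropylamino on the longer propyl chain would be the telling comparison. From the compounds shown here alone, how a carboxylic acid or a tertiary amine at the chain end would read also stays open.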